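The compounds below may be only part of what the source reports. "The series", "measured", "known", "first", "only" and "open" are said of these compounds alone.

Measured compounds in the series:

Compound 1 `C=C1C[C@]23C[C@@]1(O)CC[C@H]2c1ccc(OS(=O)(=O)c2ccc(C)cc2)c(C)c1[C@@H]3Cn1cc(-c2ccc(Br)cc2)nn1`: in a functional assay on HL-60 cells (Homo sapiens) for cytotoxicity, read by MTT assay, with a stated time of 4 days (on this read-out lower numbers stand for stronger inhibition and higher numbers for weaker inhibition), compound 1 gives > 20000 nM, which is a limit of the assay.
Compound 2 `C=C1C[C@]23C[C@@]1(O)CC[C@H]2c1ccc(OS(=O)(=O)c2ccc(C)cc2)c(C)c1[C@@H]3Cn1cc(-c2ccc(OC)cc2)nn1`: in this assay compound 2 gives > 20000 nM, again a limit of the assay.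
Compound 3 `C=C1C[C@]23C[C@@]1(O)CC[C@H]2c1ccc(O)c(C)c1[C@@H]3Cn1cc(-c2ccc(OC)cc2)nn1`: in this assay compound 3 gives > 20000 nM, also a limit of the assay.

Within the data shown here, compound 2 therefore stands at the limit in this assay, the common position of every value so far (the limit of > 20000 nM in this assay, at which 3 of the 3 values shown sit). The change under consideration leads to compound 4 `C=C1C[C@]23C[C@@]1(O)CC[C@H]2c1ccc(OS(=O)(=O)c2ccc(C)cc2)c(C)c1[C@@H]3Cn1cc(-c2ccc(C)cc2)nn1`: methyl in place of methoxy on an aromatic carbon.

Among the measured compounds shown here, two measured steps touch the same region of the series: a step that the two limits leave unreadable from compound 1 to compound 2 and a step that the two limits leave unreadable from compound 2 to compound 3. Neither can be read as a size, since both ends sit at the limit. For the measured compounds named here, exchanging the group on the six-membered aromatic ring of carbon only, or putting hydrogen in place of (4-methylphenyl)sulfonyl, brought no compound into the measurable range.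

No step beyond the scatter can thus be derived, and the expectation is that compound 4 also reaches only the limit. Compound 4 is estimated at 30000 nM, within 10000 nM to 100000 nM. The expected step is a step that the limit leaves unreadable from compound 2 to compound 4, none beyond the scatter.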

Compound 4, half-maximal inhibitory concentration: > 20000 nM
Compound 4: only a limit was reported (the forecaster's own chance of this, stated with the estimate: 85%); the middle value is on the limit's open side.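

In this assay compound 4 gives > 20000 nM as a limit of the assay. The steps from compound 1 and from compound 2 to compound 4 cannot be read, as all three values are limits. The compounds shown leave open which change, if any, would give a measurable value.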